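Swapping the ring on the quinoline core of a hormone receptor ligand

A few compounds are considered here, and "the series" means these few. Any claim that something is new, unique, unknown or untested is made for them only; others in the source may bear on it.

Three compounds share one core and differ only in the group on the aromatic carbon next to the ring nitrogen. Compound 1 `CN(c1ccc2cc(NC(=O)CCc3ccc(C(F)(F)F)cc3)ccc2n1)C1CCCC1` gives 2 nM in an assay on isolated protein for displacement of a labelled ligand from melanin-concentrating hormone receptor 1 (Homo sapiens); a higher number here means a weaker inhibitor, a lower number a stronger inhibitor. Compound 3 `O=C(CCc1ccc(C(F)(F)F)cc1)Nc1ccc2nc(N3CCCC3)ccc2c1`, carrying a plain pyrrolidin-1-yl, gives 3 nM; 3 nM (2 entries) in this assay. Compound 2 `O=C(CCc1ccc(C(F)(F)F)cc1)Nc1ccc2nc(N3CCC(c4ccccc4)C3)ccc2c1`, with 3-phenylpyrrolidin-1-yl, gives 25 nM and thus stands highest of the two single numbers here, with compound 1 as its nearest neighbour.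

Compound 4 `O=C(CCc1ccc(C(F)(F)F)cc1)Nc1ccc2nc(N3CC4CCC3C4)ccc2c1` is the new compound. The change from compound 2 is a group of 7 heavy atoms (6 carbon, 1 nitrogen; one five-membered non-aromatic ring of carbon only, one five-membered non-aromatic ring with 1 hetero atom) in place of a group of 11 heavy atoms (10 carbon, 1 nitrogen; one five-membered non-aromatic ring with 1 hetero atom, one six-membered aromatic ring of carbon only), on an aromatic carbon.

Within the data shown here, only one measured step bears on this: a 13-fold higher number from compound 1 to compound 2 (1.10 log units; beyond the scatter), a large step in the weaker direction when the phenyl-bearing ring enters. Removing that phenyl-bearing ring again, and bringing in a smaller bicyclic amine instead, is therefore expected to move the number back down, by an amount beyond the scatter. Compound 4 is expected to give 5 nM in this assay, most likely between 2 nM and 15 nM. This estimate corresponds to a 5.0-fold lower number from compound 2 to compound 4 (0.70 log units; beyond the scatter).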

Compound 4, half-maximal inhibitory concentration: 1 nM
Compound 4: the middle estimate sits 5.0-fold (0.70 log units) above what was measured; the measured number lies below the stated range.
By their numbers in this assay, from the lowest: compounds 4 and 1 (each within the scatter of the next); then compound 2.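

In this assay the step of a 25-fold lower number from compound 2 to compound 4 (1.40 log units; beyond the scatter) shows that a bridged bicyclic amine on this aromatic carbon can give a number far lower than the 3-phenylpyrrolidin-1-yl group does. The step of a 2.0-fold lower number from compound 1 to compound 4 (0.30 log units; within the scatter) then sets this bicyclic group level with cyclopentyl(methyl)amino, so groups with equal heavy-atom counts, one holding a single ring and the other two, give numbers that cannot be told apart here. Nothing measured on these compounds explains why the numbers at this position change.

Going by these compounds, it stays open whether a methyl or a hydroxyl on the pyrrolidin-1-yl ring would raise the number as the phenyl does. The shown compounds also leave open how a piperidine or a morpholine ring would behave on this carbon.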